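This account rests on a few compounds, and the source may have more. Where it says the series, first, only, none or still open, it means among the compounds named here.

Going by the values given here, compound 1 `CN1C[C@H](C(=O)Nc2ccc(F)cc2)[C@@H](c2ccc(/C=C/C(=O)Nc3ccccc3N)cc2)C1` gives 5 mL/min/kg in an in vitro ADME assay on microsomes from liver (Homo sapiens) for pharmacokinetics, read by LC-MS, with a stated time of 10 min, tested at 1 uM (on this read-out lower numbers stand for slow clearance and higher numbers for fast clearance), the lowest of the three numbers measured so far. Compound 2 `Cc1ccc(NC(=O)[C@H]2CN(C)C[C@@H]2c2ccc(/C=C/C(=O)Nc3ccccc3N)cc2)cc1` gives 15 mL/min/kg in this assay, and compound 3 `CN1C[C@H](C(=O)Nc2ccc(F)c(Br)c2)[C@@H](c2ccc(/C=C/C(=O)Nc3ccccc3N)cc2)C1` gives 15 mL/min/kg. The change from compound 1 was a 3.0-fold higher number from compound 1 to compound 2 (0.48 log units; beyond the scatter) and likewise a 3.0-fold higher number from compound 1 to compound 3 (0.48 log units; beyond the scatter), while no change at the digits printed from compound 2 to compound 3 (within the scatter). Compound 4 `Cc1ccc(NC(=O)[C@H]2CN(C)C[C@@H]2c2ccc(/C=C/C(=O)Nc3ccccc3N)cc2)cn1` differs from compound 1 by 6-methylpyridin-3-yl in place of 4-fluorophenyl on an amide-type nitrogen. Both measured steps away from compound 1 alter this same ring and both raise the number, yet neither swaps the whole ring as here, so the direction is uncertain. The expected step is a 1.8-fold higher number from compound 1 to compound 4 (0.26 log units; within the scatter), a small rise at most. Compound 4 is estimated at 9 mL/min/kg, most likely between 4 mL/min/kg and 20 mL/min/kg.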

Compound 4, clearance: 8 mL/min/kg
Beside the measured number, compound 4's estimate is 1.1-fold (0.05 log units) above it; the measured number falls inside the stated range.
By their numbers in this assay, from the lowest: compounds 1, 4, 2 and 3 (each within the scatter of the next, the first and the last beyond it).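

Exchanging the whole ring on this amide-type nitrogen, with a ring nitrogen now in the group, gives a 1.6-fold higher number from compound 1 to compound 4 (0.20 log units; within the scatter) and a 1.9-fold lower number from compound 3 to compound 4 (0.27 log units; within the scatter) and a 1.9-fold lower number from compound 2 to compound 4 (0.27 log units; within the scatter) in this assay. Compound 4 therefore cannot be told apart from any of the other three, although compound 1 is separated from compound 2 and compound 3 beyond the scatter. No measurement here explains this result.

The compounds shown leave open whether the ring nitrogen or the methyl matters more, which plain pyridin-3-yl or 6-fluoropyridin-3-yl would help to separate. On these data alone, how a ring carrying an amine or a carboxylic acid would read at this position also remains open.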